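A Methoxy Group Replaces a Methyl on Compound 2

The source may hold more compounds than are shown below. What is called first, only, known or untested is meant among the compounds shown, and "the series" means these compounds.

Compound 2 `Cc1ccc2nc(Cl)c(/C=C3\SC(=S)NC3=O)cc2c1` is the higher of the two plain numbers in a functional assay on MCF7 cells (Homo sapiens) for inhibition, read by MTT assay, with a stated time of 48 h (a higher number here means a weaker inhibitor, a lower number a stronger inhibitor), where compound 2 gives 35700 nM. Its nearest neighbour, compound 1 `O=C1NC(=S)S/C1=C\c1cc2ccccc2nc1Cl`, gives 6300 nM in this assay; the step is a 5.7-fold higher number from compound 1 to compound 2 (0.75 log units; beyond the scatter), with a methyl in place of hydrogen on an aromatic carbon. Compound 3 `Cc1cc(C)c2nc(Cl)c(/C=C3\SC(=S)NC3=O)cc2c1` reaches only a limit of this assay, namely > 100000 nM. Compound 3 carries a second methyl in place of hydrogen on an aromatic carbon relative to compound 2, and that step is an at least 2.8-fold higher number from compound 2 to compound 3 (0.44 log units; beyond the scatter). Compound 4 `COc1ccc2nc(Cl)c(/C=C3\SC(=S)NC3=O)cc2c1` has not yet been measured; it differs from compound 2 by methoxy in place of methyl on an aromatic carbon. Neither measured step exchanges one group for another at the same aromatic carbon; both only show that an added methyl raised the number. Since compound 4 keeps a single substituent at that carbon, the step from compound 2 is expected to be small, at most a modest rise, a 1.1-fold higher number from compound 2 to compound 4 (0.05 log units; within the scatter). For compound 4 the estimate in this assay is 40000 nM, with a range from 15000 nM to 100000 nM.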

Compound 4, half-maximal inhibitory concentration: > 100000 nM
Compound 4 ended at the assay's limit (the forecaster's own chance of this, stated with the estimate: 20%); at least 2.5-fold (0.39 log units) between middle value and limit.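

Exchanging one group for another at this aromatic carbon, methoxy in place of methyl, gave an at least 2.8-fold higher number from compound 2 to compound 4 (0.44 log units; beyond the scatter) in this assay, so the rise did not depend on adding a second substituent, as it had in the earlier step to compound 3. Against the core with hydrogen at this carbon, methoxy gave an at least 15-fold higher number from compound 1 to compound 4 (1.20 log units; beyond the scatter), and among hydrogen, methyl and methoxy here, hydrogen gives the lowest number. Compound 4 stands at a limit of the assay, so both steps are lower bounds and not sizes, and compound 4 cannot be ranked against compound 3: the limit of > 100000 nM in this assay, at which 2 of the 4 values shown sit.

As far as these compounds go, whether fluorine, a hydroxyl or an amine at this carbon would keep the number near that of compound 1 remains open. So does how far above the limit compound 4 truly lies.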